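Extending an Alkyl Chain Toward a Terminal Alkyne

The source may hold more compounds than are shown below. What is called first, only, known or untested is meant among the compounds shown, and "the series" means these compounds.

Compound 1 `CCCCCc1cc2cn([C@H]3C[C@H](O)[C@@H](CO)O3)c(=O)nc2o1` and compound 2 `C=CCCCCc1cc2cn([C@H]3C[C@H](O)[C@@H](CO)O3)c(=O)nc2o1` share one core and differ only in their side chain. Both were examined in a functional assay on HEL cells (Homo sapiens) for cytotoxicity; on this read-out higher numbers stand for lower toxicity in this test and lower numbers for higher toxicity in this test. In this assay compound 1 gives only the limit > 50000 nM, a boundary of the test rather than a number. In this assay compound 2 gives only the limit > 200000 nM, again a boundary and not a figure. The step that the two limits leave unreadable from compound 1 to compound 2 is therefore of unknown size. Compound 2 thus stands at a boundary, as the limit of > 200000 nM in this assay, at which 1 of the 2 values shown sits, shows, and compound 1 at another, as the limit of > 50000 nM in this assay, at which 1 of the 2 values shown sits, shows.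

Compound 3 `C#CCCCCCc1cc2cn([C@H]3C[C@H](O)[C@@H](CO)O3)c(=O)nc2o1` is the compound not yet measured. It differs from compound 2 by propargyl in place of vinyl on a saturated chain carbon, four bonds along the chain from an aromatic carbon. Within the data shown here, the only measured step that touches this chain is unreadable because the limit of > 200000 nM in this assay, at which 1 of the 2 values shown sits, and the limit of > 50000 nM in this assay, at which 1 of the 2 values shown sits, hide its size, so no step gives a direction. With nothing pointing toward a change beyond the scatter, compound 3 is expected to stay at a boundary in this assay as well. Compound 3 is estimated at 200000 nM, within 100000 nM to 400000 nM. The expected step is a number no higher from compound 2 to compound 3 (the limit leaves the size open).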

Compound 3, half-maximal cytotoxic concentration: > 200000 nM
Compound 3: only a limit was reported; the forecaster's own chance of this, stated with the estimate: 85%; the middle value sits exactly at the limit.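

In this assay compound 3 gives > 200000 nM as a limit, a boundary of the test and not a number. Among these compounds, compound 1, compound 2 and compound 3 all stand at limits, and no step among them can be read. Still open, going by these compounds, is where their true cytotoxic concentrations lie, and whether these side chains change them at all.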